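Chloro in place of bromo in two cores

This account rests on a few compounds, and the source may have more. Where it says the series, first, only, none or still open, it means among the compounds named here.

Compound 1 `Cc1nc(C)c(-c2nn(-c3ccc(F)cc3)cc2/C=C/C(=O)c2cc(Br)ccc2O)s1` and compound 2 `Cc1nc(C)c(-c2nn(-c3ccc(F)cc3)cc2/C=C/C(=O)c2cc(Cl)ccc2O)s1` share one core; compound 3 `Cc1nc(C)c(-c2nn(-c3ccc(F)cc3)cc2C2CC(c3cc(Br)ccc3O)=NN2)s1` and the unmeasured compound 4 `Cc1nc(C)c(-c2nn(-c3ccc(F)cc3)cc2C2CC(c3cc(Cl)ccc3O)=NN2)s1` share another. The difference between the two cores is not broken down here. In an ADME assay on A549 cells (Homo sapiens) for inhibition, read by MTT assay (a lower number here means a stronger inhibitor of growth, a higher number a weaker inhibitor of growth), compound 1 gives > 250 ug/mL, which is a limit of the assay and not a number. In this assay compound 2 gives > 250 ug/mL, again a limit. The step from compound 1 to compound 2 is thus a step that the two limits leave unreadable from compound 1 to compound 2; the change is chloro in place of bromo on an aromatic carbon. In this assay, within the data shown here, compound 3 gives 81.4 ug/mL, the only number among the three measured values.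

Compound 4 differs from compound 3 by chloro in place of bromo on an aromatic carbon, the same change, at a place described in the same words, as that from compound 1 to compound 2. Because both earlier values sit at the limit of > 250 ug/mL in this assay, at which 2 of the 3 values shown sit, the measured pair gives no size for this change. The step from compound 3 to compound 4 is expected to be a 1.0-fold lower number from compound 3 to compound 4 (0.01 log units; within the scatter), kept small for want of any readable earlier step. Compound 4 is expected in this assay at 80 ug/mL, between 40 ug/mL and 180 ug/mL.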

Compound 4, concentration for 50% growth inhibition: > 250 ug/mL
Compound 4 gave a limit, no number; the forecaster's own chance of this, stated with the estimate: 20%; middle value at least 3.1-fold (0.49 log units) from the limit.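

In this assay chloro in place of bromo in the 5-bromo-2-hydroxyphenyl group gives an at least 3.0-fold higher number from compound 3 to compound 4 (0.48 log units; beyond the scatter) and so is not a neutral swap in the core of compound 3. Going by these compounds, compound 4 gives > 250 ug/mL which is a limit of the assay and not a number, so the full size of this step stays unknown. The same change in the core of compound 1 cannot be read, so the notes cannot say whether its size carries from one core to the other, because the values pile up at the assay limit: the limit of > 250 ug/mL in this assay, at which 3 of the 4 values shown sit.

Of the compounds shown, only compound 3 gives a number at 81.4 ug/mL and any reading of the series therefore rests on this single bromo compound. Open, on these data alone, is whether a methoxy group or an amine in place of bromo, on the same aromatic carbon, gives a number in this assay in either core.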